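A few compounds are considered here, and "the series" means these few. Any claim that something is new, unique, unknown or untested is made for them only; others in the source may bear on it.

In a functional assay on MGC-803 cells (Homo sapiens) for inhibition, read by sulforhodamine B assay (on this read-out lower numbers stand for stronger inhibition and higher numbers for weaker inhibition), compound 1 `Cc1ccc(NC2=CC(=O)c3c(nc4n3[C@H]3OC[C@@H](O)[C@H]3OC4)C2=O)cc1` gives 1550 nM and compound 2 `COc1ccccc1NC1=CC(=O)c2c(nc3n2[C@H]2OC[C@@H](O)[C@H]2OC3)C1=O` gives 1670 nM. The move between them, a 1.1-fold higher number from compound 1 to compound 2 (0.03 log units; within the scatter), changes nothing beyond the scatter. For compound 3 `O=C1C(N2CCCC2)=CC(=O)c2c1nc1n2[C@H]2OC[C@@H](O)[C@H]2OC1` the assay reports only a limit, > 16000 nM, so it stands at the high-number end of the three, with no exact value.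

Compound 4 `O=C1C(NC2CC2)=CC(=O)c2c1nc1n2[C@H]2OC[C@@H](O)[C@H]2OC1` carries cyclopropylamino in place of pyrrolidin-1-yl on a double-bonded ring carbon. Like the (4-methylphenyl)amino of compound 1 and the (2-methoxyphenyl)amino of compound 2, the entering group keeps the amine hydrogen that compound 3 lacks, but it has no aromatic ring. Going by the values given here, two measured steps bear on this change, an at least 10-fold higher number from compound 1 to compound 3 (1.01 log units; beyond the scatter) and an at least 9.5-fold higher number from compound 2 to compound 3 (0.98 log units; beyond the scatter), and both lie beyond the scatter. Among the compounds with values here, no measured step tests cyclopropylamino itself. A partial return towards lower numbers is therefore expected in this assay, probably smaller than those two steps.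

Compound 4 is estimated at 6000 nM, with an expected range from 2000 nM to 18000 nM. This expectation amounts to an at least 2.6-fold lower number from compound 3 to compound 4 (0.42 log units; beyond the scatter).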

Compound 4, half-maximal inhibitory concentration: > 4000 nM
Compound 4 ended at the assay's limit; the forecaster's own chance of this, stated with the estimate: 25%; the middle value lies beyond the limit too.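

In this assay the value of compound 4 is a limit, not a number: the limit of > 4000 nM in this assay, at which 1 of the 4 values shown sits. Even so, it can be read against the two arylamino compounds, with an at least 2.3-fold higher number from compound 2 to compound 4 (0.37 log units; beyond the scatter) and an at least 2.5-fold higher number from compound 1 to compound 4 (0.41 log units; beyond the scatter), so among these compounds an amine hydrogen on this double-bonded ring carbon does not by itself go with the lower numbers; an aromatic ring on the amine nitrogen is present in both compounds that reach them. The step from pyrrolidin-1-yl to cyclopropylamino cannot be read, since the value of compound 3 is also a limit: the limit of > 16000 nM in this assay, at which 1 of the 4 values shown sits.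

On these data alone, whether compound 4 differs from compound 3 at all therefore stays open. Also open, as far as these compounds go, is how a benzylamino group, a plain phenylamino group or a longer chain such as butylamino would fare at this position.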